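Working notes on cell tolerance in the series

The source may hold more compounds than are shown below. What is called first, only, known or untested is meant among the compounds shown, and "the series" means these compounds.

Compound 1 `COc1ccc(C(=O)NNc2c(Br)cccc2Br)cc1`: in a toxicity assay on MDCK cells (Canis lupus familiaris) for cytotoxicity, read by CCK-8 assay, with a stated time of 48 h (a lower number here means that less compound is tolerated, a higher number that more compound is tolerated), compound 1 gives > 100000 nM, a limit of the assay.
Compound 2 `CCCCOc1ccc(C(=O)NNc2c(Br)cccc2Br)cc1`: in this assay compound 2 gives > 100000 nM, also a limit.
Compound 3 `O=C(NNc1c(Br)cccc1Br)c1ccc(OCC(F)(F)F)cc1`: in this assay compound 3 gives > 100000 nM, again a limit.

Compound 3 thus stands only at a limit, and the two further values sit at that same limit (the limit of > 100000 nM in this assay, at which 3 of the 3 values shown sit). The steps a step that the two limits leave unreadable from compound 1 to compound 2, a step that the two limits leave unreadable from compound 1 to compound 3 and a step that the two limits leave unreadable from compound 2 to compound 3 are all unreadable, each ending at the limit, so the chain on the oxygen has shown no readable effect on tolerance. Compound 4 `COC(=O)c1ccc(C(=O)NNc2c(Br)cccc2Br)cc1` differs by methoxycarbonyl in place of 2,2,2-trifluoroethoxy on an aromatic carbon. Among the measured compounds shown here, no measured step bears on this exchange, and with the whole series at the limit no direction can be drawn. Compound 4 is expected to remain tolerated near the limit, an expected step that the limit leaves unreadable from compound 3 to compound 4. The estimate for compound 4 is 150000 nM, in the range 50000 nM to 500000 nM.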

Compound 4, half-maximal cytotoxic concentration: 87600 nM
For compound 4 the middle estimate is 1.7-fold (0.23 log units) above the measured one; the range from low to high includes it.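

Methoxycarbonyl on this aromatic carbon, para to a large group, gives the first number in this assay that is not a limit, so a change at this position can now be read. The exchange gives an at least 1.1-fold lower number from compound 3 to compound 4 (0.05 log units; that floor lies within the scatter) and an at least 1.1-fold lower number from compound 2 to compound 4 (0.05 log units; that floor lies within the scatter) and an at least 1.1-fold lower number from compound 1 to compound 4 (0.05 log units; that floor lies within the scatter) as its steps, so a real drop in tolerance is neither shown nor excluded. Each step is only a floor, set by the limit on the other side: the limit of > 100000 nM in this assay, at which 3 of the 4 values shown sit.

Going by these compounds, how far these steps extend beyond their floors stays open. Also open, on these data alone, is whether an amine or a carboxylic acid on this carbon would give a lower number in this assay.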